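Rearranging the Side Chain: Compound 3 to Compound 4

The source may report more compounds than this note shows. Statements on the series, on what has been measured and on what is new or still open speak of the compounds shown alone.

In a functional assay on the whole organism (arterial blood) with Rattus norvegicus as the target (a higher number here means that more compound is needed for the effect, a lower number that less compound is needed), compound 1 (`CCCC(CC(=O)N1CCC(Cn2c(C)nc3cnccc32)CC1)c1ccccc1`) gives 0.0079 mg/kg and compound 2 (`Cc1nc2cnccc2n1CC1CCN(C(=O)CC(C)(C)c2ccccc2)CC1`) gives 0.012 mg/kg while compound 3 (`Cc1nc2cnccc2n1CC1CCN(C(=O)N[C@H](C)c2ccccc2)CC1`) gives 0.017 mg/kg on the same scale. Compound 3 and compound 2 lie within the scatter of each other. Compound 1 has a lower number than compound 3, and that gap lies beyond the scatter.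

Compound 4 (`Cc1nc2cnccc2n1CC1CCN(C(=O)CN(C)c2ccccc2)CC1`) has the same atoms as compound 3, joined differently. It carries (methyl(phenyl)amino)methyl in place of (1-phenylethyl)amino on a carbonyl carbon whose other neighbours are an amide-type nitrogen in a ring ((methyl(phenyl)amino)methyl in place of (1-phenylethyl)amino on a carbonyl carbon).

Among the compounds with values here, only one measured step bears on this change, and only indirectly. It exchanges 1-phenylbutyl for 1-methyl-1-phenylethyl on a saturated chain carbon bound to a carbonyl carbon, and it stays within the scatter (a 1.5-fold higher number from compound 1 to compound 2 (0.18 log units; within the scatter)). Within the data shown here, no measured pair shows this particular rearrangement, so the expectation rests on compound 3 and carries a wide range. In this assay no step beyond the scatter is expected, and the estimated step is small (a 1.2-fold higher number from compound 3 to compound 4 (0.07 log units; within the scatter)). The estimate for compound 4 is 0.02 mg/kg (expected range 0.007 mg/kg to 0.06 mg/kg).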

Compound 4, dose for 50% inhibition: 0.31 mg/kg
The estimate for compound 4 lay 16-fold (1.19 log units) below the measured number; the whole stated range lies below it.
By their numbers in this assay, from the lowest: compounds 1, 2 and 3 (each within the scatter of the next, the first and the last beyond it); then compound 4.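

The earlier compounds shown here suggested that this part of the molecule, on a carbonyl carbon whose other neighbours are an amide-type nitrogen in a ring, could absorb a change of group in this assay with little consequence, whereas this rearrangement of the same atoms gives a large step (an 18-fold higher number from compound 3 to compound 4 (1.26 log units; beyond the scatter)). Placed on a saturated chain carbon bound to a carbonyl carbon, methyl(phenyl)amino also stands well apart from 1-methyl-1-phenylethyl (a 26-fold higher number from compound 2 to compound 4 (1.41 log units; beyond the scatter)) and from 1-phenylbutyl (a 39-fold higher number from compound 1 to compound 4 (1.59 log units; beyond the scatter)), so among these four compounds only compound 4 stands apart, with all three of its steps large. Nothing available explains why this rearrangement costs so much.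

The change from compound 3 to compound 4 removes a hydrogen-bond donor and a defined stereocentre and also moves the nitrogen, so these compounds cannot show which of these differences carries the step. Going by these compounds, a compound with (phenylamino)methyl on the same carbonyl carbon, or with methyl(1-phenylethyl)amino there, would differ from compound 4 or compound 3 in a single feature, and how either would read on this scale remains open.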